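Two ways of attaching a dipropylamino group to one core

A few compounds are considered here, and "the series" means these few. Any claim that something is new, unique, unknown or untested is made for them only; others in the source may bear on it.

Compound 1 `CN1CCN(CC(=O)N2CCN(c3ccnc4cc(Cl)ccc34)CC2)CC1` gives 79800 nM.
Compound 2 `CN1CCN(CCNc2ccnc3cc(Cl)ccc23)CC1` gives 16700 nM.
Compound 3 `CCCN(CCC)CCNc1ccnc2cc(Cl)ccc12` gives 14900 nM.

These numbers come from a toxicity assay (L6 cells) for inhibition, with Rattus norvegicus as the target, read by resazurin assay, with a stated time of 70 h; a lower number here means a stronger inhibitor, a higher number a weaker inhibitor. Compound 2 and compound 3 differ only by dipropylamino in place of 4-methylpiperazin-1-yl on a saturated chain carbon, two bonds along the chain from a nitrogen on an aromatic ring, and this change moved the number by a 1.1-fold lower number from compound 2 to compound 3 (0.05 log units; within the scatter). Compound 1 carries a different core; the difference between the two cores is not broken down here, and its number stands well apart from the other two.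

Compound 4 `CCCN(CCC)CC(=O)N1CCN(c2ccnc3cc(Cl)ccc23)CC1` has not yet been measured. It differs from compound 1 by dipropylamino in place of 4-methylpiperazin-1-yl on a saturated chain carbon bound to a carbonyl carbon. Among the compounds with values here, this is the same kind of change as the one from compound 2 to compound 3, but its place differs: here the saturated chain carbon is bound to a carbonyl carbon, whereas there it was two bonds along the chain from a nitrogen on an aromatic ring.

Because the earlier step was a 1.1-fold lower number from compound 2 to compound 3 (0.05 log units; within the scatter), the step for compound 4 is expected to be about as small, a 1.1-fold lower number from compound 1 to compound 4 (0.04 log units; within the scatter). Compound 4 is therefore estimated at 72000 nM, with a likely range from 30000 nM to 170000 nM.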

Compound 4, half-maximal inhibitory concentration: 70500 nM
For compound 4 the middle estimate is 1.0-fold (0.01 log units) above the measured one; measured number inside the range.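

In this assay, putting dipropylamino in place of 4-methylpiperazin-1-yl on the core of compound 1 gives a 1.1-fold lower number from compound 1 to compound 4 (0.05 log units; within the scatter), so on this core the two groups cannot be told apart. Set beside the earlier step on the other core, the exchange reads the same on both: the same change on two cores in this assay, a 1.1-fold lower number (0.05 log units; within the scatter) from compound 2 to compound 3 and a 1.1-fold lower number (0.05 log units; within the scatter) from compound 1 to compound 4, 1.0-fold (0.00 log units) apart, within the scatter of two such steps

This shows that, on these two cores, the exchange stays too small to read, but it does not show that it would stay so small on any further core, and it gives no reason why the two groups match.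

The compounds shown leave open whether other amines at this place, such as morpholine or dimethylamino, would match these two groups, or whether a group without nitrogen, such as a plain butyl chain or a carboxylic acid, would move the number. They also leave open which part of the difference between the two cores matters for the number.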